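The source may report more compounds than this note shows. Statements on the series, on what has been measured and on what is new or still open speak of the compounds shown alone.

Working notes on the series. Compound 1 `Cc1ccc(-n2cc(CN3C(=O)C[C@@H]4CC[C@@]3(C)C4(C)C)nn2)cc1` gives 400 nM in a functional assay on A549 cells (Homo sapiens) for inhibition, read by MTT assay, with a stated time of 24 h (on this read-out higher numbers stand for weaker inhibition and lower numbers for stronger inhibition), the second highest of the three numbers: compound 3 `CC1(C)[C@H]2CC[C@]1(C)N(Cc1cn(-c3cccc(C#N)c3)nn1)C(=O)C2`, with 440 nM, sits within the scatter of it, while compound 2 `CC1(C)[C@H]2CC[C@]1(C)N(Cc1cn(-c3cccc(Br)c3)nn1)C(=O)C2`, with 90 nM, lies furthest off, a 4.4-fold lower number from compound 1 to compound 2 (0.65 log units; beyond the scatter). The remaining measured steps are a 1.1-fold higher number from compound 1 to compound 3 (0.04 log units; within the scatter) and a 4.9-fold higher number from compound 2 to compound 3 (0.69 log units; beyond the scatter). Compound 4 `CC1(C)[C@H]2CC[C@]1(C)N(Cc1cn(-c3ccc(O)cc3)nn1)C(=O)C2` has not yet been measured in this assay; it differs from compound 1 by hydroxy in place of methyl on an aromatic carbon. Among the compounds with values here, no measured step bears directly on this change: the steps so far either replace the whole substituted phenyl or exchange cyano for bromo, and none brings in a hydroxy or removes a methyl. The three measured numbers cover only a modest spread, so no step beyond the scatter is expected from compound 1 to compound 4, with a generous range to allow for an untested group. Compound 4 is therefore estimated to give 500 nM in this assay, between 150 nM and 1600 nM. The expected step is a 1.3-fold higher number from compound 1 to compound 4 (0.10 log units; within the scatter).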

Compound 4, half-maximal inhibitory concentration: 140 nM
Beside the measured number, compound 4's estimate is 3.6-fold (0.55 log units) above it; measured number outside the range, below it.
By their numbers in this assay, from the lowest: compounds 2 and 4 (each within the scatter of the next); then compounds 1 and 3 (each within the scatter of the next).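

The exchange of methyl for hydroxy on an aromatic carbon, para to a large group, gives a 2.9-fold lower number from compound 1 to compound 4 (0.46 log units; beyond the scatter) in this assay, so a single heavy-atom change at this position moves the number beyond the scatter. Within the data shown here, the step of a 3.1-fold lower number from compound 3 to compound 4 (0.50 log units; beyond the scatter) is also beyond the scatter, whereas a 1.6-fold higher number from compound 2 to compound 4 (0.19 log units; within the scatter) stays within it, so the 4-hydroxyphenyl group reaches the level earlier seen only with the 3-bromophenyl group. Nothing available accounts for the effect of this change.

On these data alone, it remains open whether methoxy or an amine on this same aromatic carbon would follow hydroxy or methyl. Also open, as far as these compounds go, is whether bromo and cyano would keep their gap if placed on this carbon.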